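Homoserine lactone amides against colorectal cancer cells

The source may hold more compounds than are shown below. What is called first, only, known or untested is meant among the compounds shown, and "the series" means these compounds.

Compound 1 `O=C(CCCCCc1ccccc1)N[C@H]1CCOC1=O` — > 100000 nM
Compound 2 `O=C(CCCCCCCCc1ccccc1)N[C@H]1CCOC1=O` — > 100000 nM
Compound 3 `O=C(CCCc1ccccc1)CC(=O)N[C@H]1CCOC1=O` — > 100000 nM

Three amides of the same lactone core were tested in a functional assay on NCI-H630 cells (Homo sapiens) for cytotoxicity, read by sulforhodamine B assay, with a stated time of 5 days; a lower number here means a stronger inhibitor, a higher number a weaker inhibitor. In this assay compound 1 reaches only the limit of the measurement, > 100000 nM. Compound 2, whose chain is longer, gives likewise only the limit, > 100000 nM. Compound 3, which carries a second carbonyl in its chain, also sits at the limit, > 100000 nM. Compound 2 therefore stands with the other two at the edge of what the assay can report, and no number separates it from them, as the limit of > 100000 nM in this assay, at which 3 of the 3 values shown sit, shows.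

Compound 4 `O=C(CCCCCCCCCCc1ccccc1)N[C@H]1CCOC1=O` has not yet been measured in this assay. It differs from compound 2 by phenethyl in place of phenyl on a saturated chain carbon, eight bonds along the chain from a carbonyl carbon. Among the compounds with values here, no step between measured compounds is available to guide the expectation, since every value so far is a limit. Given that compound 2 sits at > 100000 nM, the step from compound 2 to compound 4 is expected to be none beyond the scatter, a number no higher from compound 2 to compound 4 (the limit leaves the size open). For compound 4 the estimate in this assay is 100000 nM, with a range from 30000 nM to 300000 nM, and most likely again only a limit will be reported.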

Compound 4, half-maximal inhibitory concentration: 70000 nM
Beside the measured number, compound 4's estimate is 1.4-fold (0.15 log units) above it; low and high end bracket the measured number.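

Compound 4, with phenethyl in place of phenyl on a saturated chain carbon, eight bonds along the chain from a carbonyl carbon, is the only compound shown that gives a number rather than a limit in this assay. Going by these compounds, the change gives an at least 1.4-fold lower number from compound 2 to compound 4 (0.15 log units; that floor lies within the scatter); this is only a floor, so the true size of the step remains unknown, and the data do not establish a real gain from compound 2 to compound 4. What the result adds is that this position on the chain can carry phenethyl and still give a readable value, while the other three compounds remain at the edge of what the assay reports: the limit of > 100000 nM in this assay, at which 3 of the 4 values shown sit.

The compounds shown leave open whether a still longer chain would lower the number further, and whether an amine or a carboxylic acid in place of phenethyl at this position would also give a readable value. They also leave open how much the shared core contributes, as all four compounds carry it unchanged.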